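Dropping one bromo from the higher of two paw-edema numbers

The compounds below may be only part of what the source reports. "The series", "measured", "known", "first", "only" and "open" are said of these compounds alone.

Measured compounds:
compound 1, `O=c1cc(CNc2nc(-c3cc4cc(Br)cc(Br)c4oc3=O)cs2)c2cc(Cl)ccc2[nH]1`, 21.9%
compound 2, `O=c1cc(CNc2nc(-c3cc4cc(Br)cc(Br)c4oc3=O)cs2)c2ccc(Cl)cc2[nH]1`, 41.5%

Two compounds that share the same core but carry the chloro group in different positions were tested in a functional assay on the whole organism for inhibition, with Rattus norvegicus as the target, read by paw edema, in the formalin test, with a stated time of 8 h, at a dose of 100 mg/kg by the intraperitoneal route; on this read-out lower numbers stand for less inhibition and higher numbers for more inhibition at the one dose given (going by the name of the read-out). Compound 1 gave 21.9%, and compound 2 gave 41.5%. Of the two numbers, compound 2 stands highest; its nearest neighbour, compound 1, lies below it by a gap beyond the usual scatter, so compound 2 gives the higher inhibition of the pair on this read-out.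

Compound 3, `O=c1cc(CNc2nc(-c3cc4cc(Br)ccc4oc3=O)cs2)c2ccc(Cl)cc2[nH]1`, departs from compound 2 by a single change: hydrogen in place of bromo on an aromatic carbon. Bromo leaves and hydrogen enters on an aromatic carbon of the fused two-ring system, where a second bromo group remains. Among the compounds with values here, no measured pair shows what such a change does here, so the expectation rests on compound 2 alone. A small step downward, or none beyond the scatter, is expected from compound 2 to compound 3, a number 6.5 percentage points lower from compound 2 to compound 3 (within the scatter). Compound 3 is estimated to give 35% in this assay, within a range of 15% to 55%.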

Compound 3, a percentage reported as inhibition, in the whole organism at one dose (the size of the read-out at that dose, not a potency): 24.5%
Compound 3: middle estimate off by 10.5 percentage points, on the high side; measured number inside the range.
By their numbers in this assay, from the lowest: compounds 1 and 3 (each within the scatter of the next); then compound 2.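

In this assay, hydrogen in place of bromo on an aromatic carbon of a six-membered aromatic ring, part of a fused system of two rings and meta to a bromo group, gives a number 17 percentage points lower from compound 2 to compound 3 (beyond the scatter). This is the first pair shown to isolate this carbon: with the other bromo group and the rest of the structure unchanged, losing this one bromo group alone produces a modest step that stands clear of the scatter, so the group at this carbon is not silent on this read-out. Nothing at hand explains why the number falls with this change.

The compounds shown carry only bromo or hydrogen at this carbon, so they leave open whether a methoxy group or an amine there would hold the number seen for compound 2 or fall as compound 3 does. Also open, from the compounds shown here alone, are whether removing the remaining bromo group would bring a step of its own, and whether the same change would give a similar step with the chloro group placed as in compound 1.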